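Vinylcarbonyl on the ring nitrogen of compound 1

A few compounds are considered here, and "the series" means these few. Any claim that something is new, unique, unknown or untested is made for them only; others in the source may bear on it.

In a functional assay on NCI-H460 cells (Homo sapiens) for antiproliferative activity, read by sulforhodamine B assay, with a stated time of 48 h (on this read-out lower numbers stand for stronger inhibition of growth and higher numbers for weaker inhibition of growth), compound 1 (`O=C1/C(=C/c2ccc3ccccc3c2)CNC/C1=C\c1ccc2ccccc2c1`) gives 24500 nM and compound 2 (`O=C1/C(=C/c2c[nH]c3ccccc23)CNC/C1=C\c1c[nH]c2ccccc12`) gives 6100 nM in the same read-out. Compound 1 therefore holds the higher of the two numeric values, with a gap beyond the scatter. Compound 3 (`O=C1/C(=C/c2c[nH]cn2)CNC/C1=C\c1c[nH]cn1`) reads > 100000 nM in this assay, which is a limit of the assay. Compound 4 (`C=CC(=O)N1C/C(=C\c2ccc3ccccc3c2)C(=O)/C(=C/c2ccc3ccccc3c2)C1`) departs from compound 1 by vinylcarbonyl in place of hydrogen on an amine nitrogen in a ring. Within the data shown here, no measured pair shows this change, so the following is expectation only: a move to a lower number in this assay, beyond the scatter. The expected size is a 4.9-fold lower number from compound 1 to compound 4 (0.69 log units; beyond the scatter) (estimated). For compound 4 the estimated value is 5000 nM (range 1200 nM to 20000 nM).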

Compound 4, concentration for total growth inhibition: 5500 nM
For compound 4 the middle estimate is 1.1-fold (0.04 log units) below the measured one, within the range that was stated.
By their numbers in this assay, from the lowest: compounds 4 and 2 (each within the scatter of the next); then compound 1. At a limit, above all of these: compound 3.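

Among these compounds, with vinylcarbonyl in place of hydrogen on the ring amine nitrogen, this assay shows a 4.5-fold lower number from compound 1 to compound 4 (0.65 log units; beyond the scatter), the first single-place step. The hydrogen on this nitrogen is therefore not needed for growth inhibition on the core of compound 1, and this position accepts a substituent with a gain. Nothing shown gives a reason for the step.

Open, as far as these compounds go, is whether the vinyl double bond matters or the carbonyl alone suffices, which an acetyl or propanoyl on the same nitrogen would test. Also open, from the compounds shown here alone, is whether the same change has a similar effect on compound 2.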